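The source may hold more compounds than are shown below. What is called first, only, known or untested is meant among the compounds shown, and "the series" means these compounds.

Measured compounds in this series:
- compound 1, `C[C@@]12CCCC[C@H]1CC=C(O)C2=O`: 119000 nM
- compound 2, `C[C@H]1N=C2C[C@H]3C[C@H](C3(C)C)[C@@]2(C)OC1=O`: 42000 nM
- compound 3, `CC(C)(C)OC(=O)n1cnc(C[C@H]2N=C3C[C@H]4C[C@H](C4(C)C)[C@@]3(C)OC2=O)c1`: 147000 nM

All three were read in a functional assay on PC-3 cells (Homo sapiens) for antiproliferative activity, read by sulforhodamine B assay, with a stated time of 48 h; a lower number here means a stronger inhibitor, a higher number a weaker inhibitor. Compound 2 gives the lowest number of the three in this assay; compound 1 stands nearest to it, and compound 3 furthest, and both gaps lie beyond the scatter, so compound 2 counts as the strongest inhibitor among the measured compounds, though still a weak one on the absolute scale.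

The next compound, compound 4, `CC1(C)[C@H]2CC3=NCC(=O)O[C@]3(C)[C@@H]1C2`, is not yet measured. Against compound 2 it differs in one place: hydrogen in place of methyl on a saturated ring carbon.

Among the measured compounds shown here, no measured pair shows this kind of change, so its effect in this assay is not anchored by data. The removal is small, and all three measured numbers sit in a narrow, weak band, so the expectation is a step of no more than the scatter in either direction, if anything a slight drift toward a higher number. For compound 4 the estimate in this assay is 60000 nM, within 20000 nM to 180000 nM. That estimate corresponds to an expected 1.4-fold higher number from compound 2 to compound 4 (0.15 log units; within the scatter).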

Compound 4, half-maximal inhibitory concentration: > 300000 nM
Compound 4 ended at the assay's limit (the forecaster's own chance of this, stated with the estimate: 15%); at least 5.0-fold (0.69 log units) between middle value and limit.
By their numbers in this assay, from the lowest: compound 2; then compounds 1 and 3 (each within the scatter of the next). At a limit, above all of these: compound 4.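

In this assay compound 4 gives > 300000 nM as a limit of the assay, not a number. The methyl on the saturated ring carbon next to the ring nitrogen therefore matters in this series: hydrogen in its place gives an at least 7.1-fold higher number from compound 2 to compound 4 (0.85 log units; beyond the scatter) and provides the first single-place step, one that lies beyond the scatter. The full size of the step cannot be read, and the value of compound 4 marks only where the assay stops: the limit of > 300000 nM in this assay, at which 1 of the 4 values shown sits.

Going by these compounds, only methyl and hydrogen are compared at this carbon, so the effect of an ethyl or aminomethyl group there remains open, including whether either would improve on compound 2 (42000 nM). Also open, on these data alone, is whether the loss on removing this methyl would carry over to a compound bearing a larger substituent at this carbon.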